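The compounds below may be only part of what the source reports. "The series", "measured", "known", "first", "only" and "open" are said of these compounds alone.

Going by the values given here, in an ADME assay for permeability (a higher number here means that the compound crosses the layer faster, a lower number that the compound crosses the layer more slowly), compound 1 `CNC(=O)c1cc(C(=O)N[C@H]2CC[C@H](O)CC2)n([C@@H](C)c2ccccc2)n1` gives 80 nm/s, the lower of the two numbers measured so far. The other number belongs to compound 2 `CNC(=O)c1cc(C(=O)N[C@H]2CC[C@H](O)CC2)n([C@@H](C)c2ccc(C(F)(F)F)cc2)n1`, at 270 nm/s. Among the compounds with values here, the only measured step, a 3.4-fold higher number from compound 1 to compound 2 (0.53 log units; beyond the scatter), is trifluoromethyl in place of hydrogen on an aromatic carbon, and it lies beyond the scatter.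

Compound 3 `CNC(=O)c1cc(C(=O)N[C@H]2[C@@H]3C[C@@H](O)C[C@@H]32)n([C@@H](C)c2ccccc2)n1` keeps the core of compound 1 and differs only in the group on the amide-type nitrogen: a group of 7 heavy atoms (6 carbon, 1 oxygen; one three-membered non-aromatic ring of carbon only, one five-membered non-aromatic ring of carbon only) in place of a group of 7 heavy atoms (6 carbon, 1 oxygen; one six-membered non-aromatic ring of carbon only), on an amide-type nitrogen. Within the data shown here, no measured step touches that group, so the trifluoromethyl step bears on this change only indirectly, as a modest reference for how far one change has moved the number. The change itself leaves the counts of heavy atoms, hydrogen-bond donors and hydrogen-bond acceptors as they were. No step beyond the scatter is therefore expected in this assay, and no direction can be supported by the data.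

For compound 3 the expected value is 90 nm/s, with an estimated range of 40 nm/s to 200 nm/s. This estimate corresponds to an expected step of a 1.1-fold higher number from compound 1 to compound 3 (0.05 log units; within the scatter).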

Compound 3, apparent permeability: 61 nm/s
Compound 3: the middle estimate sits 1.5-fold (0.17 log units) above what was measured; low and high end bracket the measured number.
By their numbers in this assay, from the lowest: compounds 3 and 1 (each within the scatter of the next); then compound 2.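

At this position, on an amide-type nitrogen, the group with one three-membered and one five-membered non-aromatic ring of carbon only can replace 4-hydroxycyclohexyl in compound 1 without a step beyond the scatter in this assay (a 1.3-fold lower number from compound 1 to compound 3 (0.12 log units; within the scatter)). Going by these compounds alone, this is the first measured change at this position, and it keeps the counts of heavy atoms, hydrogen-bond donors and hydrogen-bond acceptors while the defined stereocentres go from 2 to 4, so for this pair a different ring arrangement at equal counts leaves the read-out within the scatter. No evidence bearing on this result is at hand.

The compounds shown leave open whether this ring exchange would also stay within the scatter with the trifluoromethyl of compound 2 in place, since that pairing would test the two changes together. They also leave open how far the number would move if the hydroxyl on this group gave way to an amine or a carboxylic acid, both of which would alter the group itself rather than its ring arrangement.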